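The source may hold more compounds than are shown below. What is called first, only, known or untested is meant among the compounds shown, and "the series" means these compounds.

In an ADME assay (liver) for metabolic stability, with Liver microsome (Homo sapiens) as the target, using microsomes and NADPH, with a stated time of 30 min, tested at 1 uM (a higher number here means faster removal of the compound, a lower number slower removal), three compounds sharing one core differ only in the aromatic group it carries. Compound 1 `Cn1cc(-c2cc(C(O)(C(F)(F)F)C(F)(F)F)cnc2N2CCN(S(=O)(=O)c3ccc(N)nc3)CC2)cn1` gives 19 mL.min-1.g-1, compound 2 `CC(C)n1cc(-c2cc(C(O)(C(F)(F)F)C(F)(F)F)cnc2N2CCN(S(=O)(=O)c3ccc(N)nc3)CC2)cn1` gives 38 mL.min-1.g-1 and compound 3 `Nc1ccc(S(=O)(=O)N2CCN(c3ncc(C(O)(C(F)(F)F)C(F)(F)F)cc3-c3cnccc3F)CC2)cn1` gives 17 mL.min-1.g-1. Compound 3 stands level with its nearest neighbour, the step being a 1.1-fold lower number from compound 1 to compound 3 (0.05 log units; within the scatter). Its wider gap is a 2.2-fold lower number from compound 2 to compound 3 (0.35 log units; beyond the scatter).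

Compound 4 `Nc1ccc(S(=O)(=O)N2CCN(c3ncc(C(O)(C(F)(F)F)C(F)(F)F)cc3-c3ccc4ocnc4c3)CC2)cn1` keeps the core and changes the aromatic group once more: 1,3-benzoxazol-5-yl in place of 4-fluoropyridin-3-yl on an aromatic carbon. The two measured swaps at this place bear most directly on the change, and the larger of them is only modest. Isopropyl in place of methyl, with a 2.0-fold higher number from compound 1 to compound 2 (0.30 log units; within the scatter), is a weaker guide to what more heavy atoms might do. Among the measured compounds shown here, no measured compound carries a 1,3-benzoxazol-5-yl group, so the direction rests on slim evidence. Since this group brings in more heavy atoms than it removes, a small rise is tentatively expected, no larger than the largest step seen so far. For compound 4 the estimated change is a 1.8-fold higher number from compound 3 to compound 4 (0.25 log units; within the scatter). Compound 4 is expected to give 30 mL.min-1.g-1, with an estimated range of 14 mL.min-1.g-1 to 60 mL.min-1.g-1.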

Compound 4, intrinsic clearance in microsomes: < 14 mL.min-1.g-1
Compound 4: only a limit was reported; the forecaster's own chance of this, stated with the estimate: 3%; at least 2.1-fold (0.33 log units) between middle value and limit.
By their numbers in this assay, from the lowest: compounds 3, 1 and 2 (each within the scatter of the next, the first and the last beyond it). At a limit, below all of these: compound 4.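

In this assay compound 4 is reported only as a limit, not as a number: the limit of < 14 mL.min-1.g-1 in this assay, at which 1 of the 4 values shown sits. Among the compounds shown here, the 1,3-benzoxazol-5-yl group enters with more heavy atoms than the 4-fluoropyridin-3-yl group leaves, yet the number does not rise, so this aromatic carbon of the shared core carries a group with two aromatic rings without faster removal; the earlier compounds, each with a single aromatic ring here, could not show this. The firmest reading is against the isopropyl compound, an at least 2.7-fold lower number from compound 2 to compound 4 (0.43 log units; beyond the scatter), while the other two steps, an at least 1.2-fold lower number from compound 3 to compound 4 (0.08 log units; that floor lies within the scatter) and an at least 1.3-fold lower number from compound 1 to compound 4 (0.13 log units; that floor lies within the scatter), have floors that do not separate compound 4 from compound 3 or compound 1.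

From the compounds shown here alone, how far compound 4 lies beyond its limit remains unknown, and with it whether it truly differs from compound 3 and compound 1. The compounds shown also leave open whether the result follows from the second ring or from the ring oxygen, a question that a 1,3-benzothiazol-5-yl group or a plain phenyl group at this place would help to settle.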